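The compounds below may be only part of what the source reports. "The series", "measured", "known", "first", "only" and "open" are said of these compounds alone.

Series notes. The shared core of compound 1 `O=[N+]([O-])c1ccc(-c2cn3nc(Cc4ccc(Cl)cc4)sc3n2)cc1` is kept throughout. In a functional assay on HeLa cells (Homo sapiens) for cytotoxicity, with a stated time of 72 h (a higher number here means a weaker inhibitor, a lower number a stronger inhibitor), compound 1 gives > 250000 nM, which is a limit of the assay and not a number. Compound 2 `Clc1ccc(Cc2nn3c(Br)c(-c4ccc(Br)cc4)nc3s2)cc1` in this assay gives 188000 nM. Compound 3 `Cc1ccc(-c2nc3sc(Cc4ccc(Cl)cc4)nn3c2Br)cc1` has methyl in place of bromo on an aromatic carbon relative to compound 2. In this assay compound 3 gives > 250000 nM, again a limit of the assay rather than a number. The step of an at least 1.3-fold higher number from compound 2 to compound 3 (0.12 log units; that floor lies within the scatter) is accordingly only a floor, and that floor sits within the scatter. Compound 3 thus stands at the limit of > 250000 nM in this assay, at which 2 of the 3 values shown sit, with no number to place it more exactly.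

Compound 4 `O=[N+]([O-])c1ccc(-c2nc3sc(Cc4ccc(Cl)cc4)nn3c2Br)cc1` differs from compound 3 by nitro in place of methyl on an aromatic carbon. Within the data shown here, no measured step bears on this change directly: the single measured step, an at least 1.3-fold higher number from compound 2 to compound 3 (0.12 log units; that floor lies within the scatter), concerns methyl in place of bromo and gives only a floor within the scatter. Compound 1, which also carries nitro, shows only a limit. In this assay compound 4 is therefore expected around 250000 nM, within 150000 nM to 600000 nM, and most probably reported as a limit. The expected step of a number no higher from compound 3 to compound 4 (the limit leaves the size open) is none beyond the scatter.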

Compound 4, half-maximal inhibitory concentration: > 250000 nM
Compound 4 ended at the assay's limit; the forecaster's own chance of this, stated with the estimate: 75%; the middle value lies on the limit itself.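

In this assay compound 4 gives > 250000 nM, a limit of the assay and not a number. On the aromatic carbon of the six-membered aromatic ring of carbon only, para to a large group, nitro in place of bromo gives an at least 1.3-fold higher number from compound 2 to compound 4 (0.12 log units; that floor lies within the scatter), so nitro, like methyl, yields only a floor that stays within the scatter. The steps to compound 4 from compound 3 and from compound 1 cannot be read, and most of the series now sits at one limit: the limit of > 250000 nM in this assay, at which 3 of the 4 values shown sit.

Open, as far as these compounds go, is whether any group at this position other than the bromo of compound 2 gives a measurable number in this assay, for instance an amine or a carboxylic acid. Also open, from the compounds shown here alone, is what bromo in place of hydrogen on an aromatic carbon of the shared core does, as no readable value yet bears on that change.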